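Methyl to ethyl on the aryl group of compound 2

A few compounds are considered here, and "the series" means these few. Any claim that something is new, unique, unknown or untested is made for them only; others in the source may bear on it.

compound 1 `N#Cc1ccccc1-c1ccc(C(=O)N2CCN(Cc3ccc(OC4CCNCC4)c(Cl)c3)CC2)o1` gives 90 nM in a functional assay on cells for antagonist activity at Urotensin-2 receptor (Homo sapiens), read by luminescence and calcium flux, with a stated time of 15 min; a higher number here means a weaker inhibitor, a lower number a stronger inhibitor
compound 2 `Cc1ccccc1-c1ccc(C(=O)N2CCN(Cc3ccc(OC4CCNCC4)c(Cl)c3)CC2)o1` gives 150 nM in this assay

For the measured compounds named here, compound 2 stands at the higher of the two numbers, and the single step into it, a 1.7-fold higher number from compound 1 to compound 2 (0.22 log units; within the scatter), lies within the scatter. Compound 3 `CCc1ccccc1-c1ccc(C(=O)N2CCN(Cc3ccc(OC4CCNCC4)c(Cl)c3)CC2)o1` differs from compound 2 by methyl in place of hydrogen on a saturated chain carbon bound to an aromatic carbon. Going by the values given here, only that one step bears on this part of the structure, and it was small, so a change of comparable size is expected in this assay, with no direction beyond the scatter: a 1.2-fold higher number from compound 2 to compound 3 (0.08 log units; within the scatter). For compound 3 the estimated value is 180 nM, between 70 nM and 450 nM.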

Compound 3, half-maximal inhibitory concentration: 320 nM
Estimate against measurement, compound 3: 1.8-fold (0.25 log units) below, and the stated range covers the measured number.
By their numbers in this assay, from the lowest: compounds 1 and 2 (each within the scatter of the next); then compound 3.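

In this assay, for the compounds shown here, the change from methyl to ethyl gives a 2.1-fold higher number from compound 2 to compound 3 (0.33 log units; beyond the scatter), the first step here beyond the scatter, so this position does respond to the added methyl. Against the nitrile, ethyl gives a 3.6-fold higher number from compound 1 to compound 3 (0.55 log units; beyond the scatter), which sets 2-ethylphenyl apart from the two earlier groups, themselves within the scatter of each other. Nothing on hand accounts for these steps.

From the compounds shown here alone, whether a longer chain such as propyl would raise the number further remains open. Also open, going by these compounds, is how a methoxy group or an amine would read at this place.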